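Chloro for allyloxy on the phenyl ring of compound 2

The source may report more compounds than this note shows. Statements on the series, on what has been measured and on what is new or still open speak of the compounds shown alone.

Three compounds sharing one core have been examined in a functional assay on the whole organism (Cricetulus griseus) with Cricetinae gen. sp. as the target; on this read-out lower numbers stand for an effect already at smaller amounts and higher numbers for an effect only at larger amounts of compound. Compound 1 `Cc1ccccc1-c1n[nH]c(-c2ccccc2)n1` gives 0.3 mg/kg; 0.3 mg/kg (2 entries) in two entries of this assay. Compound 2 `C=CCOc1cccc(-c2nc(-c3ccccc3C)n[nH]2)c1` gives 0.15 mg/kg in this assay and so stands at the lowest of the two single numbers at hand. Compound 3 `Cc1cccc(-c2n[nH]c(-c3ccccc3C)n2)c1` gives 4 mg/kg in this assay, a number lying beyond the scatter above that of compound 2.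

Compound 4 `Cc1ccccc1-c1n[nH]c(-c2cccc(Cl)c2)n1` has not yet been measured in this assay. It differs from compound 2 in one place: chloro in place of allyloxy on an aromatic carbon, that is, on an aromatic carbon of a six-membered aromatic ring of carbon only, meta to a large group.

For the measured compounds named here, no step between measured compounds covers this exchange. The picture is that compound 1, bare at that place, gives 0.3 mg/kg; 0.3 mg/kg (2 entries), while compound 3, carrying a methyl there, gives 4 mg/kg; a small group at that place has thus once gone with a higher number. Compound 4 is therefore expected to show a step of a 6.7-fold higher number from compound 2 to compound 4 (0.82 log units; beyond the scatter) toward a higher number, beyond the scatter. The estimate for compound 4 in this assay is 1 mg/kg, with a range from 0.25 mg/kg to 5 mg/kg.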

Compound 4, dose for half-maximal effect: 0.6 mg/kg
Compound 4: the middle estimate sits 1.7-fold (0.22 log units) above what was measured; the measured number falls inside the stated range.
By their numbers in this assay, from the lowest: compound 2; then compound 4; then compound 3.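

In this assay, the exchange gives the first step read directly at this position, a 4.0-fold higher number from compound 2 to compound 4 (0.60 log units; beyond the scatter), so allyloxy goes with a lower number than chloro on this aromatic carbon. The result also separates two small groups at that place: compound 4 with its chloro gives 0.6 mg/kg, whereas compound 3 with its methyl gives 4 mg/kg, and compound 4 lies within the usual scatter of compound 1, which is bare at that place and gives 0.3 mg/kg; 0.3 mg/kg (2 entries). Nothing available explains why these groups differ in this way.

From the compounds shown here alone, what an amine, a carboxylic acid or a longer chain would give on this aromatic carbon remains open, as does the result for a methoxy group, the only one of these to keep the oxygen of allyloxy while losing its double bond. A propoxy group, which would keep the chain length and oxygen of allyloxy without the double bond, would be needed to show whether that double bond has any part in the lower number of compound 2.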